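Swapping the Fluorophenylethyl Arm: Cytotoxicity Outlook for Compound 4

The source may report more compounds than this note shows. Statements on the series, on what has been measured and on what is new or still open speak of the compounds shown alone.

Compound 1, `CCOc1ccc(CN(Cc2ccc(C(C)(C)C)cc2)Cc2cc3cc(C)ccc3[nH]c2=O)cc1`. In a toxicity assay on MDCK cells (Canis lupus familiaris) for cytotoxicity, read by crystal violet staining, with a stated time of 48 h (a lower number here means that less compound is tolerated, a higher number that more compound is tolerated), compound 1 gives > 10000 nM, which is a limit of the assay rather than a number.
Compound 2, `CCCOc1ccc(CN(Cc2ccc(C(C)(C)C)cc2)Cc2cc3cc(C)ccc3[nH]c2=O)cc1`. In this assay compound 2 gives > 5000 nM, also only a limit.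
Compound 3, `Cc1ccc2[nH]c(=O)c(CN(Cc3ccc(C(C)(C)C)cc3)C(C)c3ccc(F)cc3)cc2c1`. In this assay compound 3 gives > 33000 nM, again a limit.

Compound 3 therefore stands at the limit of > 33000 nM in this assay, at which 1 of the 3 values shown sits, and the two other values shown are limits as well, namely the limit of > 10000 nM in this assay, at which 1 of the 3 values shown sits, and (the limit of > 5000 nM in this assay, at which 1 of the 3 values shown sits). Compound 4 is `Cc1ccc2[nH]c(=O)c(CN(Cc3ccc(C(C)(C)C)cc3)Cc3ccc(N(C)C)c(Cl)c3)cc2c1`, and the change from compound 3 is 3-chloro-4-(dimethylamino)benzyl in place of 1-(4-fluorophenyl)ethyl on an amine nitrogen. Three measured steps exist, but none of them reads: a step that the two limits leave unreadable from compound 1 to compound 2, a step that the two limits leave unreadable from compound 1 to compound 3 and a step that the two limits leave unreadable from compound 2 to compound 3. Among the measured compounds shown here, none of these steps touches the entering 3-chloro-4-(dimethylamino)benzyl group, so no measured step bears directly on the change. With every value shown sitting at a limit, no step beyond the scatter is expected in this assay in either direction. Compound 4 is expected to give about 33000 nM, within the range 8000 nM to 100000 nM. The estimated step is a number no higher from compound 3 to compound 4 (the limit leaves the size open), expected to remain within the scatter, most likely as a further limit.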

Compound 4, half-maximal cytotoxic concentration: > 10000 nM
Compound 4: a limit, no number; the forecaster's own chance of this, stated with the estimate: 70%; the middle value is on the limit's open side.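

In this assay compound 4 gives > 10000 nM, which is a limit and not a number. Its steps to compound 1, compound 2 and compound 3 therefore cannot be read. The compounds shown leave open at what concentration any of the four harms the cells, and whether changing the groups on the amine nitrogen shifts cytotoxicity at all.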